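Moving the side chain of compound 2

The source may report more compounds than this note shows. Statements on the series, on what has been measured and on what is new or still open speak of the compounds shown alone.

compound 1 `COc1cc(N2CCN(C(=O)N3CCN(C)CC3)CC2)ccc1Nc1nc(NC2CCCCC2)c2nc[nH]c2n1` gives 17 nM
compound 2 `COc1cc(N2CCC(C(=O)N3CCC(N(C)C)C3)CC2)ccc1Nc1nc(NC2CCCCC2)c2nc[nH]c2n1` gives 58 nM

In a functional assay on HCT-116 cells (Homo sapiens) for cytotoxicity (on this read-out higher numbers stand for weaker inhibition and lower numbers for stronger inhibition), compound 2 has the higher number of the two, and its gap to compound 1 lies beyond the scatter. Compound 3 `COc1cc(N2CCC(CC(=O)N3CCN(C)CC3)CC2)ccc1Nc1nc(NC2CCCCC2)c2nc[nH]c2n1` keeps the shared core but has ((4-methylpiperazin-1-yl)carbonyl)methyl in place of (3-(dimethylamino)pyrrolidin-1-yl)carbonyl on a saturated ring carbon. Among the measured compounds shown here, no measured pair shows this change directly, so the forecast is loose. Compound 1 also carries a 4-methylpiperazin-1-yl carbonyl group and gives 17 nM, which suggests a small move toward stronger inhibition. The expected step is modest, perhaps within the scatter (a 1.9-fold lower number from compound 2 to compound 3 (0.29 log units; within the scatter)). Compound 3 is estimated at 30 nM (range 10 nM to 100 nM).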

Compound 3, half-maximal inhibitory concentration: 51 nM
For compound 3 the middle estimate is 1.7-fold (0.23 log units) below the measured one; the range from low to high includes it.
By their numbers in this assay, from the lowest: compound 1; then compounds 3 and 2 (each within the scatter of the next).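

In this assay, placing ((4-methylpiperazin-1-yl)carbonyl)methyl on the saturated ring carbon in place of (3-(dimethylamino)pyrrolidin-1-yl)carbonyl gives a 1.1-fold lower number from compound 2 to compound 3 (0.06 log units; within the scatter), so the two numbers cannot be told apart. This position therefore accepts a rearrangement of the same atoms, including a six-membered ring for a five-membered one, without a step beyond the scatter. Nothing available here gives a reason for this result. On these data alone, what remains open is whether a carboxylic acid or a longer chain on this ring carbon would also stay within the scatter.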